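The source may report more compounds than this note shows. Statements on the series, on what has been measured and on what is new or still open speak of the compounds shown alone.

Measured so far in an ADME assay on microsomes from liver (Rattus norvegicus) for metabolic stability, read by LC-MS, using NADPH, with a stated time of 30 min, tested at 0.1 uM, in the presence of a further agent that is not named here; on this read-out lower numbers stand for a less stable compound and higher numbers for a more stable compound:
compound 1 `Nc1ccc(-c2cnc(N)c(-c3ccc(N)nc3)n2)cn1` gives > 90%
compound 2 `Nc1ncc(-c2ccc(C(=O)N3CC[C@@H](O)C3)cc2)nc1-c1ccc(C(F)(F)F)cc1` gives > 90%
compound 3 `Nc1ccc(-c2nc(-c3ccc(S(=O)(=O)C4CC4)cc3)cnc2N)cn1` gives > 90%

Among the compounds with values here, the series so far offers only (the limit of > 90% in this assay, at which 3 of the 3 values shown sit). Compound 2 gives > 90%, which is a limit of the assay and not a number. The entries for the other two compounds are limits as well, so no order among the three can be read.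

Compound 4 `Nc1ncc(-c2ccc(C(=O)N3CCC(O)CC3)cc2)nc1-c1ccc(C(F)(F)F)cc1` has yet to be measured in this assay. It carries 4-hydroxypiperidin-1-yl in place of 3-hydroxypyrrolidin-1-yl on a carbonyl carbon. The five-membered non-aromatic ring gives way to a six-membered one, the defined stereocentre leaves, and the rest of compound 2 stays as it is.

Within the data shown here, no pair of measured compounds differs in one place, so no measured step is available as a guide. The expectation therefore rests on compound 2 at > 90% and on the modest size of the change. The step expected a number no higher from compound 2 to compound 4 (the limit leaves the size open) stays within the scatter, with any real shift more likely toward a less stable compound. Compound 4 is expected at 90%, with an estimated range from 75% to 99%.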

Compound 4, percent of the compound remaining: > 90%
Compound 4 ended at the assay's limit; the forecaster's own chance of this, stated with the estimate: 50%; the middle value lies on the limit itself.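

No step can be read from compound 2 to compound 4 in this assay, as both entries are limits of the assay and not numbers. The compounds shown leave open how they rank against one another and which change, if any, would bring a value off this limit: the limit of > 90% in this assay, at which 4 of the 4 values shown sit.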